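Allyl to furan-2-yl on an aromatic ether oxygen

The compounds below may be only part of what the source reports. "The series", "measured", "known", "first", "only" and "open" are said of these compounds alone.

In a functional assay on HeLa cells (Homo sapiens) for cytotoxicity (a lower number here means a stronger inhibitor, a higher number a weaker inhibitor), compound 1 `O=C(OC1=CC(=O)c2ccccc2C1=O)c1ccccc1` gives 55000 nM, compound 2 `C=CCOc1ccc2c(c1)C(=O)C=CC2=O` gives 27200 nM and compound 3 `CS(=O)(=O)OC1=CC(=O)c2ccccc2C1=O` gives 7610 nM. Compound 2 therefore holds the middle of the three numbers, with its gaps to compound 1 and compound 3 both beyond the scatter. Compound 4 `O=C1C=CC(=O)c2cc(Oc3ccco3)ccc21` carries furan-2-yl in place of allyl on an oxygen on an aromatic ring. Going by the values given here, no measured pair shows this kind of change, so only the spread of the three values guides the expectation. In this assay, a small move toward a lower number is expected, perhaps not beyond the scatter, and the estimated step is a 1.7-fold lower number from compound 2 to compound 4 (0.23 log units; within the scatter). The estimate for compound 4 is 16000 nM, with an expected range from 5000 nM to 50000 nM.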

Compound 4, half-maximal inhibitory concentration: 17200 nM
Estimate against measurement, compound 4: 1.1-fold (0.03 log units) below; low and high end bracket the measured number.
By their numbers in this assay, from the lowest: compound 3; then compounds 4 and 2 (each within the scatter of the next); then compound 1.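

In this assay, going by these compounds alone, the exchange of allyl for furan-2-yl on an oxygen on an aromatic ring gives a 1.6-fold lower number from compound 2 to compound 4 (0.20 log units; within the scatter) and so provides the first reading at this position. The oxygen therefore carries a five-membered aromatic ring with 1 hetero atom as well as an open allyl chain, with no separation between the two groups in this read-out. Nothing measured here accounts for this result.
Still open, from the compounds shown here alone, is whether an aminoethyl group, a carboxylic acid or a longer alkyl chain on this oxygen would move the number beyond the scatter. Also open, going by these compounds, is whether the same exchange would read alike on another core.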